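Pyridinyl for Thiophenyl on a Shared Core: Compound 4

A few compounds are considered here, and "the series" means these few. Any claim that something is new, unique, unknown or untested is made for them only; others in the source may bear on it.

Of the compounds shown here, three built on one shared core have been measured in a functional assay on HCT-15 cells (Homo sapiens) for cytotoxicity, read by CCK-8 assay and cell counting, with a stated time of 2 days; a lower number here means a stronger inhibitor, a higher number a weaker inhibitor. Compound 1 `Oc1ccc(-c2cc(-c3cccc(Cl)c3)nc(-c3ccccn3)c2)cc1` gives 28200 nM. Compound 2 `Oc1cccc(-c2cc(-c3ccc(Cl)cc3)nc(-c3cccs3)c2)c1` gives 9280 nM, the second highest of the three numbers, while compound 3 `Oc1cccc(-c2cc(-c3cccc(Cl)c3)nc(-c3cccs3)c2)c1` gives 2610 nM. Within the data shown here, the only step between compounds differing in a single place, a 3.6-fold lower number from compound 2 to compound 3 (0.55 log units; beyond the scatter), concerns the chlorophenyl group and says nothing about the five-membered ring.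

Compound 4 `Oc1cccc(-c2cc(-c3ccc(Cl)cc3)nc(-c3cccnc3)c2)c1` differs from compound 2 in one place: pyridin-3-yl in place of thiophen-2-yl on an aromatic carbon. Among the measured compounds shown here, no measured pair in this set isolates that change. Compound 1 bears neither a thiophen-2-yl nor a pyridin-3-yl group, but it also differs from compounds 2 and 3 in its hydroxyphenyl and chlorophenyl groups, so its value in this assay cannot be read as a verdict on the ring exchange alone. With nothing in the data that speaks directly to the exchange, the step from compound 2 to compound 4 is expected to stay within the scatter, as a 1.0-fold lower number from compound 2 to compound 4 (0.01 log units; within the scatter). For the measured compounds named here, compound 4 is therefore estimated at 9000 nM, with a range from 3000 nM to 30000 nM that is deliberately wide, since no precedent in this set guides the expectation.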

Compound 4, half-maximal inhibitory concentration: 16800 nM
Beside the measured number, compound 4's estimate is 1.9-fold (0.27 log units) below it, within the range that was stated.
By their numbers in this assay, from the lowest: compound 3; then compounds 2, 4 and 1 (each within the scatter of the next, the first and the last beyond it).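

In this assay, among these compounds, the exchange on this aromatic carbon, next to the ring nitrogen, can now be read directly for the first time (a 1.8-fold higher number from compound 2 to compound 4 (0.26 log units; within the scatter)). The earlier compounds shown here offered only a step in the chlorophenyl group, whereas this pair shows that compound 2 and compound 4, one carrying a five-membered aromatic ring with sulfur and the other a six-membered aromatic ring with nitrogen, cannot be told apart in this assay. No further measurement bears on this result, so it stands as a plain comparison of two numbers and gives no account of the groups themselves.

On these data alone, whether the same exchange would read alike with the 3-chlorophenyl group of compound 3 remains open, and the pyridin-2-yl group of compound 1 cannot settle where the ring nitrogen matters, since that compound differs from the others in more than one place. As far as these compounds go, how a furan-2-yl ring, a saturated piperidine ring or a pyridin-3-yl ring bearing a carboxylic acid would read at this position also remains open.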